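Bromo to Methoxy: Expected Potency of Compound 4

The source may report more compounds than this note shows. Statements on the series, on what has been measured and on what is new or still open speak of the compounds shown alone.

Of the compounds shown here, three have been tested in a functional assay on HepG2 cells (Homo sapiens) for antiproliferative activity, read by MTT assay; a higher number here means a weaker inhibitor, a lower number a stronger inhibitor. Compound 1 `COc1ccc(-c2ccnc(Nc3ccc(Cl)cc3Cl)n2)cc1` gives 190 nM. Compound 2 `Clc1ccc(Nc2nccc(-c3ccc(Br)cc3)n2)c(Cl)c1` gives 720 nM in this assay, and compound 3 `Clc1ccc(Nc2nccc(-c3ccc(Br)cc3)n2)cc1` gives 47500 nM in this assay, the highest number of the three. Compound 1 and compound 2 differ in one place, (methoxy in place of bromo on an aromatic carbon), and the step is a 3.8-fold lower number from compound 2 to compound 1 (0.58 log units; beyond the scatter). Compound 3 differs from compound 2 by hydrogen in place of chloro on an aromatic carbon, and the step is a 66-fold higher number from compound 2 to compound 3 (1.82 log units; beyond the scatter).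

Compound 4 `COc1ccc(-c2ccnc(Nc3ccc(Cl)cc3)n2)cc1` has not yet been measured. It differs from compound 3 by methoxy in place of bromo on an aromatic carbon, the same change, in the same surroundings, as the one that separates compound 2 from compound 1; this change occurs twice among the compounds shown. A step of similar size is expected for compound 4, a 3.8-fold lower number from compound 3 to compound 4 (0.58 log units; beyond the scatter), because the earlier step was a 3.8-fold lower number from compound 2 to compound 1 (0.58 log units; beyond the scatter). This rests on a single pair, so the expectation is loose. Compound 4 is therefore estimated at 12500 nM in this assay, with a likely range from 4000 nM to 40000 nM.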

Compound 4, half-maximal inhibitory concentration: 4500 nM
For compound 4 the middle estimate is 2.8-fold (0.44 log units) above the measured one; measured number inside the range.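

In this assay, methoxy in place of bromo on an aromatic carbon gave an 11-fold lower number from compound 3 to compound 4 (1.02 log units; beyond the scatter), the same direction as the earlier step but not the same size: the same change on two cores in this assay, a 3.8-fold lower number (0.58 log units; beyond the scatter) from compound 2 to compound 1 and an 11-fold lower number (1.02 log units; beyond the scatter) from compound 3 to compound 4, 2.8-fold (0.44 log units) apart, beyond the scatter of two such steps

Hydrogen in place of chloro on an aromatic carbon behaved alike, giving a 24-fold higher number from compound 1 to compound 4 (1.37 log units; beyond the scatter), again in the direction seen before and again with a different size: the same change on two cores in this assay, a 66-fold higher number (1.82 log units; beyond the scatter) from compound 2 to compound 3 and a 24-fold higher number (1.37 log units; beyond the scatter) from compound 1 to compound 4, 2.8-fold (0.44 log units) apart, beyond the scatter of two such steps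

Across these two cores, then, the direction of each change carried over and its size did not, so a step measured on one core gave the sign but not a reliable magnitude on the other; with only two pairs for each change, this shows no general rule for the series, and the numbers do not explain why the sizes differ.

The compounds shown leave open how an amine, a carboxylic acid or a longer chain such as ethoxy would behave in place of the methoxy. They also leave open whether the direction would hold on any further core.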